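This account rests on a few compounds, and the source may have more. Where it says the series, first, only, none or still open, it means among the compounds named here.

Working notes on the series. Compound 1 `COc1ccc(/C=C2\CC[C@H]3C(C)(C)CCC[C@]3(C)[C@H]2CCC(C)CC(=O)O)cc1` in an ADME assay on HUVEC cells (Homo sapiens) for cytotoxicity, read by MTT assay, with a stated time of 72 h (a higher number here means a weaker inhibitor, a lower number a stronger inhibitor), returns only a limit of the assay, > 200000 nM. Compound 2 `COc1ccc(/C=C2\CC[C@H]3C(C)(C)CCC[C@]3(C)[C@H]2CCC(C)CC(=O)O)cc1OC` likewise returns a limit, > 200000 nM. Compound 3 `CC(CC[C@H]1/C(=C/c2ccc(Cl)cc2)CC[C@H]2C(C)(C)CCC[C@]12C)CC(=O)O` in this assay again gives nothing beyond a limit, > 200000 nM. Compound 3 therefore stands exactly where the other two stand, at the limit of > 200000 nM in this assay, at which 3 of the 3 values shown sit. The steps a step that the two limits leave unreadable from compound 1 to compound 2, a step that the two limits leave unreadable from compound 1 to compound 3 and a step that the two limits leave unreadable from compound 2 to compound 3 are all unreadable against that limit. The unmeasured compound 4 `CC(CC[C@H]1/C(=C/c2ccc(Br)cc2)CC[C@H]2C(C)(C)CCC[C@]12C)CC(=O)O` differs from compound 3 by bromo in place of chloro on an aromatic carbon. All three unreadable steps change the group on the same aromatic carbon without revealing any size, so no step beyond the scatter is expected for a number no higher from compound 3 to compound 4 (the limit leaves the size open). Compound 4 is expected to stay at the limit, estimated at 200000 nM within 100000 nM to 600000 nM.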

Compound 4, half-maximal inhibitory concentration: > 200000 nM
Compound 4 was reported as a limit (the forecaster's own chance of this, stated with the estimate: 85%); the middle value lies on the limit itself.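

Compound 4 sits at the same limit as compound 1, compound 2 and compound 3, so no step among them can be read in this assay: the limit of > 200000 nM in this assay, at which 4 of the 4 values shown sit.

The compounds shown leave open how far each lies past that limit, and whether any group on this aromatic ring would give a readable value.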